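The source may hold more compounds than are shown below. What is called first, only, known or untested is meant among the compounds shown, and "the series" means these compounds.

Measured compounds and their values:

compound 1, `O=C(Nc1ccc(C(F)(F)F)cc1)c1cc(Cl)ccc1O`: 740 nM
compound 2, `O=C(Nc1ccc(Cl)c(Cl)c1)c1cc(F)ccc1O`: 760 nM
compound 3, `O=C(Nc1ccc(C(F)(F)F)cc1)c1cc(Br)ccc1O`: 610 nM

All three were tested in a functional assay on KG-1 cells (Homo sapiens) for cytotoxicity, read by luminescence and CellTiter-Glo, with a stated time of 3 days; a lower number here means a stronger inhibitor, a higher number a weaker inhibitor. Compound 1 and compound 3 share a core and differ only by bromo in place of chloro on an aromatic carbon; this change made a step of a 1.2-fold lower number from compound 1 to compound 3 (0.08 log units; within the scatter). Compound 2 rests on a different core, and how its core differs from that of compound 1 is not broken down here. Compound 4, `O=C(Nc1ccc(Br)c(Cl)c1)c1cc(F)ccc1O`, is not yet measured; it differs from compound 2 by bromo in place of chloro on an aromatic carbon. Among the compounds with values here, this is the same kind of change as the one from compound 1 to compound 3, not the same change: there the place was meta to a large group and para to a hydroxy group, here it is ortho to a chloro group and para to a large group. Because the earlier step was a 1.2-fold lower number from compound 1 to compound 3 (0.08 log units; within the scatter), a step of about a 1.1-fold lower number from compound 2 to compound 4 (0.05 log units; within the scatter) is expected from compound 2 to compound 4 in this assay. For compound 4 the estimate is 680 nM, expected to lie between 340 nM and 1400 nM.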

Compound 4, half-maximal inhibitory concentration: 670 nM
Estimate against measurement, compound 4: 1.0-fold (0.01 log units) above; low and high end bracket the measured number.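

In this assay, putting bromo in place of chloro gives a 1.1-fold lower number from compound 2 to compound 4 (0.05 log units; within the scatter). Set beside the same swap on the other core, the two steps agree: the same change on two cores in this assay, a 1.2-fold lower number (0.08 log units; within the scatter) from compound 1 to compound 3 and a 1.1-fold lower number (0.05 log units; within the scatter) from compound 2 to compound 4, 1.1-fold (0.03 log units) apart, within the scatter of two such steps This shows that, for these two pairs, the swap behaves alike on both cores, even though it sits at a different place on each, but neither step shows that bromo truly changes the number, and two pairs cannot show that the match holds on further cores.

The compounds shown leave open what a group other than a halogen would do at this place, such as an amine or a carboxylic acid. They also leave open whether any such group would give a step larger than the scatter.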